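Adding a methoxy to the core of compound 1

The source may report more compounds than this note shows. Statements on the series, on what has been measured and on what is new or still open speak of the compounds shown alone.

Measured so far in a functional assay on T29Kt1 cells (Homo sapiens) for cytotoxicity, read by sulforhodamine B assay, with a stated time of 3 days; on this read-out lower numbers stand for stronger inhibition and higher numbers for weaker inhibition:
- compound 1 (`OCc1cn(Cc2ccc(Cl)cc2)c2ccccc12`): 79 nM
- compound 2 (`Cc1ccc(Cn2cc(CO)c3ccccc32)cc1`): 150 nM
- compound 3 (`OCc1cn(Cc2ccc(Cl)c(Cl)c2)c2ccccc12`): 310 nM

Compound 1 stands at the low end of these numbers, and compound 2 lies within the scatter of it. Compound 4 (`COc1ccc2c(c1)c(CO)cn2Cc1ccc(Cl)cc1`) is still unmeasured and differs from compound 1 by methoxy in place of hydrogen on an aromatic carbon. Two measured steps offer guidance, but both lie elsewhere in the molecule. Swapping chloro for methyl gave a 1.9-fold higher number from compound 1 to compound 2 (0.28 log units; within the scatter). The closer parallel, adding a further chloro in place of hydrogen, gave a 3.9-fold higher number from compound 1 to compound 3 (0.59 log units; beyond the scatter). A slight lean towards a higher number is therefore expected, but no clear step beyond the scatter. The estimated step is a 1.6-fold higher number from compound 1 to compound 4 (0.22 log units; within the scatter). Compound 4 is expected at 130 nM. The estimated range for compound 4 runs from 35 nM to 450 nM.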

Compound 4, half-maximal inhibitory concentration: 12500 nM
Compound 4: middle estimate off by 96-fold (1.98 log units), on the low side; the measured number lies above the stated range.
By their numbers in this assay, from the lowest: compounds 1 and 2 (each within the scatter of the next); then compound 3; then compound 4.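

In this assay, methoxy in place of hydrogen on an aromatic carbon of the core gives a 160-fold higher number from compound 1 to compound 4 (2.20 log units; beyond the scatter). For the compounds shown here, the earlier steps were all made on the other ring, so this is the first sign that the core is far less forgiving of a change at this carbon. No measurement shown gives a reason for the size of this step.

The compounds shown leave open whether the loss belongs to methoxy itself or to any added group at this carbon. Fluoro or an amine here would help separate those two readings.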